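A few compounds are considered here, and "the series" means these few. Any claim that something is new, unique, unknown or untested is made for them only; others in the source may bear on it.

Compound 1 `COc1ccc(C(=O)Nc2cccc(Cl)c2Cl)cc1OC1CCCC1` — > 200000 nM, a limit of the assay. Compound 2 `COc1ccc(C(=O)Nc2ccccc2C(F)(F)F)cc1OC1CCCC1` — 3100 nM. Compound 3 `COc1ccc(C(=O)Nc2ccccc2C(=O)c2ccccc2)cc1OC1CCCC1` — 1700 nM.

In an assay on isolated protein for inhibition of phosphodiesterase 4A (Sus scrofa) (a lower number here means a stronger inhibitor, a higher number a weaker inhibitor), compound 1 sits at the limit of > 200000 nM in this assay, at which 1 of the 3 values shown sits, so only a limit is known for it. For the measured compounds named here, compounds 2 and 3 give numbers, and the one measured step between them, a 1.8-fold lower number from compound 2 to compound 3 (0.26 log units; within the scatter), exchanges a group on an aromatic carbon. Compound 4 `COc1ccc(C(=O)Nc2cnccn2)cc1OC1CCCC1` differs from compound 1 at another place: pyrazin-2-yl in place of 2,3-dichlorophenyl on an amide-type nitrogen. No measured step covers a change at the amide-type nitrogen, so the size of the move in this assay cannot be read from the shown data. Compound 4 is expected to give a number rather than a limit, estimated at 2000 nM with a range of 300 nM to 20000 nM, a step of an at least 100-fold lower number from compound 1 to compound 4 (2.00 log units; beyond the scatter).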

Compound 4, half-maximal inhibitory concentration: 250 nM
Beside the measured number, compound 4's estimate is 8.0-fold (0.90 log units) above it; the whole stated range lies above it.
By their numbers in this assay, from the lowest: compound 4; then compounds 3 and 2 (each within the scatter of the next). At a limit, above all of these: compound 1.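

For the compounds shown here, at the amide-type nitrogen, pyrazin-2-yl in place of 2,3-dichlorophenyl gives an at least 800-fold lower number from compound 1 to compound 4 (2.90 log units; beyond the scatter) in this assay, so the group on this nitrogen can move the number far beyond the scatter, which the one earlier step, an exchange on an aromatic carbon, did not show. Compound 1 stands at a limit, so the step has no fixed size: the limit of > 200000 nM in this assay, at which 1 of the 4 values shown sits.

The compounds shown leave open whether the move follows from the two ring nitrogens of pyrazin-2-yl or from the loss of the two chlorines. Unsubstituted phenyl or pyridin-2-yl on the same nitrogen would separate these two changes.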